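Compound 3: Fluoro in Place of Trifluoromethoxy

The source may hold more compounds than are shown below. What is called first, only, known or untested is meant among the compounds shown, and "the series" means these compounds.

Two members of this series have so far been tested for cytotoxicity. In an ADME assay on Huh-7 cells (Homo sapiens) for cytotoxicity (on this read-out lower numbers stand for higher toxicity in this test and higher numbers for lower toxicity in this test), compound 1 `CCCN1CCC(CNCc2cn(-c3ccc(C(F)(F)F)cc3)nc2-c2ccc(C(F)(F)F)cc2)CC1` gives 1200 nM. In this assay compound 2 `Cc1ccccc1-c1nn(-c2ccc(OC(F)(F)F)cc2)cc1CNCCN1CCN(C)CC1` gives 17000 nM, the higher of the two numbers and therefore the less toxic of the pair, a gap beyond the usual scatter of the test. Among the compounds with values here, no two measured compounds differ in only one place, so no single change has yet been read directly from measurements.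

Compound 3 `Cc1ccccc1-c1nn(-c2ccc(F)cc2)cc1CNCCN1CCN(C)CC1` is the next member awaiting measurement in this assay. It differs from compound 2 in one place: fluoro in place of trifluoromethoxy on an aromatic carbon. Cut one bond further out, the same difference reads 4-(trifluoromethoxy)phenyl to 4-fluorophenyl.

Within the data shown here, with no measured single-change step to lean on, the expectation rests on compound 2 alone. Because compound 2 already gives 17000 nM, the expected step of a 1.5-fold higher number from compound 2 to compound 3 (0.17 log units; within the scatter) is small and, if anything, toward a higher number, not clearly beyond the scatter. Compound 3 is thus expected to give about 25000 nM in this assay, within a range from 8000 nM to 60000 nM.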

Compound 3, half-maximal cytotoxic concentration: > 20000 nM
Compound 3 was reported as a limit; the forecaster's own chance of this, stated with the estimate: 25%; the middle value lies beyond the limit too.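

In this assay compound 3 gives > 20000 nM as a limit of the assay and not as a number. Within the data shown here, the exchange of 4-(trifluoromethoxy)phenyl for 4-fluorophenyl is the first single change that can be read, and it gives an at least 1.1-fold higher number from compound 2 to compound 3 (0.07 log units; that floor lies within the scatter) with a floor that cannot separate it from no change. At this aromatic carbon, para to a large group, going from the 5 heavy atoms of trifluoromethoxy to the 1 of fluoro therefore shows no move toward higher toxicity in this test, although the full size of the step cannot be read because compound 3 is reported only as a limit: the limit of > 20000 nM in this assay, at which 1 of the 3 values shown sits.

The compounds shown leave open how far the number for compound 3 lies past that limit, and so whether the step in fact goes beyond the scatter. They also leave open whether a different group on this aromatic carbon, such as an amine, a carboxylic acid or a longer chain, would keep the number this high or bring it down toward higher toxicity.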